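The source may hold more compounds than are shown below. What is called first, only, known or untested is meant among the compounds shown, and "the series" means these compounds.

Compound 3 `CC[C@@H](C)[C@H](NC(=O)c1ccc(C(CC)(CC)c2ccc(OCC(O)C(C)(C)C)c(C)c2)n1CC)C(=O)O` stands lowest of the three numbers available: in an assay on HL-60 cells for agonist activity at vitamin D3 receptor (Homo sapiens), read by microscopy, with a stated time of 96 h (on this read-out lower numbers stand for an effect already at smaller amounts and higher numbers for an effect only at larger amounts of compound), compound 3 gives 2.3 nM. Compound 1 `CCN(CC)CCCNC(=O)c1ccc(C(CC)(CC)c2ccc(OCC(O)C(C)(C)C)c(C)c2)n1CC`, which carries a 3-(diethylamino)propyl chain on the amide nitrogen instead, gives 66 nM in this assay, and compound 2 `CCn1c(C(=O)N(C)CCC#N)ccc1C(CC)(CC)c1ccc(OCC(O)C(C)(C)C)c(C)c1`, with a (2-cyanoethyl)(methyl)amino group on the carbonyl carbon, gives 1960 nM. The two measured steps into compound 3 are both large: a 29-fold lower number from compound 1 to compound 3 (1.46 log units; beyond the scatter) and an 850-fold lower number from compound 2 to compound 3 (2.93 log units; beyond the scatter). Compound 4 `CCn1c(C(=O)Nc2ccc(OC(F)(F)F)cc2)ccc1C(CC)(CC)c1ccc(OCC(O)C(C)(C)C)c(C)c1` differs from compound 3 by 4-(trifluoromethoxy)phenyl in place of 1-carboxy-2-methylbutyl on an amide-type nitrogen. This removes the group whose arrival brought the lowest number, and what enters has no hydrogen-bond donor and resembles neither of the other two measured side groups. The steps of a 29-fold lower number from compound 1 to compound 3 (1.46 log units; beyond the scatter) and an 850-fold lower number from compound 2 to compound 3 (2.93 log units; beyond the scatter) therefore bear on it only in direction: on their evidence, losing the 1-carboxy-2-methylbutyl group is expected to raise the number in this assay well beyond the scatter, though how far cannot be read from the compounds shown. Compound 4 is expected to land at 400 nM in this assay, within a range of 60 nM to 3000 nM, which means an expected step of a 170-fold higher number from compound 3 to compound 4 (2.24 log units; beyond the scatter).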

Compound 4, half-maximal effective concentration: > 50000 nM
Compound 4: a limit, no number; the forecaster's own chance of this, stated with the estimate: 5%; at least 120-fold (2.09 log units) between middle value and limit.
By their numbers in this assay, from the lowest: compound 3; then compound 1; then compound 2. At a limit, above all of these: compound 4.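

Compound 4 gives a limit of the assay, not a number, in this assay: the limit of > 50000 nM in this assay, at which 1 of the 4 values shown sits. For the compounds shown here, with the shared core unchanged, the change on the amide-type nitrogen to 4-(trifluoromethoxy)phenyl goes with an at least 21000-fold higher number from compound 3 to compound 4 (4.33 log units; beyond the scatter), a larger step than any among the earlier compounds. The compound also falls past both other compounds, with an at least 25-fold higher number from compound 2 to compound 4 (1.40 log units; beyond the scatter) and an at least 750-fold higher number from compound 1 to compound 4 (2.87 log units; beyond the scatter), so this place can carry the read-out well beyond what compound 2 had shown as the high end of the series.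

What stays open is which part of the change goes with the loss: the carboxylic acid leaving, the aromatic ring entering or the trifluoromethoxy group on that ring, as the compounds shown change all three at once. Also open, on these data alone, is whether a phenyl ring carrying a carboxylic acid on this nitrogen would restore a low number, and whether a shorter chain bearing the same carboxylic acid, or the opposite configuration at the two stereocentres of the 1-carboxy-2-methylbutyl group, would hold it.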